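Methylating a Sulfonamide Nitrogen: A Measured Pair and a Prediction

A few compounds are considered here, and "the series" means these few. Any claim that something is new, unique, unknown or untested is made for them only; others in the source may bear on it.

Of the compounds shown here, three have been tested in a functional assay on the whole organism for inhibition, with Mus musculus as the target; a higher number here means that more compound is needed for the effect, a lower number that less compound is needed: compound 1 `CCN1CCCC1CNC(=O)c1cc(N(C)S(C)(=O)=O)c(C)cc1OC`, compound 2 `CCN1CCCC1CNC(=O)c1cc(NS(C)(=O)=O)c(C)cc1OC` and compound 3 `CCN1CCCC1CNC(=O)c1cc(NS(N)(=O)=O)ccc1OC`. In this assay compound 1 gives 26.1 mg/kg. Compound 2 gives 35.6 mg/kg in this assay. For compound 3 this assay reports only a limit and no number, > 50 mg/kg; this is the limit of > 50 mg/kg in this assay, at which 1 of the 3 values shown sits.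

Compound 1 and compound 2 differ in one place: methyl in place of hydrogen on a sulfonamide nitrogen. The step from one to the other is a 1.4-fold lower number from compound 2 to compound 1 (0.13 log units; within the scatter), so the two values cannot be told apart.

Compound 4 `CCN1CCCC1CNC(=O)c1cc(N(C)S(N)(=O)=O)ccc1OC` has not yet been measured in this assay. It differs from compound 3 by methyl in place of hydrogen on a sulfonamide nitrogen, the same change that turns compound 2 into compound 1, at a place described in the same words. The difference between the cores of compound 2 and compound 3 is not broken down here.

The expectation for compound 4 rests on the measured pair: because a 1.4-fold lower number from compound 2 to compound 1 (0.13 log units; within the scatter), the same change is expected to move compound 4 little from compound 3, a step estimated as a step that the limit leaves unreadable from compound 3 to compound 4. Since compound 3 reached only a limit, compound 4 is expected to give 70 mg/kg, most likely again as a limit rather than a number. The expected range for compound 4 runs from 35 mg/kg to 150 mg/kg.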

Compound 4, dose for half-maximal effect: > 50 mg/kg
Compound 4: only a limit was reported; the forecaster's own chance of this, stated with the estimate: 75%; the middle value is on the limit's open side.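

In this assay compound 4 gives > 50 mg/kg, which is a limit and not a number. No step between compound 3 and compound 4 can be read, since both compounds reached only a limit: the limit of > 50 mg/kg in this assay, at which 2 of the 4 values shown sit.

The compounds shown leave open what dose compound 3 and compound 4 actually need, and whether methyl in place of hydrogen on a sulfonamide nitrogen changes that dose on this core.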